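A Second Methoxy Group Tested Against Ovarian Cancer Cells

A few compounds are considered here, and "the series" means these few. Any claim that something is new, unique, unknown or untested is made for them only; others in the source may bear on it.

Three compounds have been measured in a functional assay on SK-OV-3 cells (Homo sapiens) for cytotoxicity, read by sulforhodamine B assay, with a stated time of 48 h, tested at 1 uM; a lower number here means a stronger effect, a higher number a weaker effect of the compound at the concentration tested:

Compound 1 `COc1ccc(-c2cc(/C=C/C(=O)c3ccc(N)cc3)[nH]n2)cc1` gives 105%
Compound 2 `COc1ccc(C(=O)/C=C/c2cc(-c3cc(OC)c(OC)c(OC)c3)n[nH]2)cc1OC` gives 100%
Compound 3 `COc1ccc(C(=O)/C=C/c2cc(-c3cc(OC)c(OC)c(OC)c3)n[nH]2)cc1` gives 98%

Compound 1 gives the highest of the three numbers, but its gaps to compound 2 and compound 3 are both within the scatter, so no order among them can be claimed. Compound 4 `COc1ccc(-c2cc(/C=C/C(=O)c3ccc(N)cc3)[nH]n2)cc1OC` differs from compound 1 by methoxy in place of hydrogen on an aromatic carbon. Among the measured compounds shown here, the one measured step that bears on this change, a number 2 percentage points lower from compound 2 to compound 3 (within the scatter), removes rather than adds a methoxy group and stays within the scatter. No shift beyond the scatter is therefore expected in this assay. Compound 4 is estimated at 103%, with a range from 90% to 115%. For compound 4 the expected step is a number 2 percentage points lower from compound 1 to compound 4 (within the scatter).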

Compound 4, a percentage reported as activity, at one concentration (the size of the read-out at that concentration, not a potency): 97%
Compound 4: middle estimate off by 6 percentage points, on the high side; measured number inside the range.
By their numbers in this assay, from the lowest: compounds 4, 3, 2 and 1 (each within the scatter of the next).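

In this assay, methoxy in place of hydrogen, ortho to a methoxy group, gives a number 8 percentage points lower from compound 1 to compound 4 (within the scatter), so on the core of compound 1 this change shows no effect that can be told from the scatter. The change has now been seen on two cores, and the two steps cannot be told apart: the same change on two cores in this assay, a number 2 percentage points lower (within the scatter) from compound 2 to compound 3 and a number 8 percentage points higher (within the scatter) from compound 4 to compound 1, 10 percentage points apart, within the scatter of two such steps

From the compounds shown here alone, whether a hydroxyl group or a fluorine atom at this position would give a number beyond the scatter stays open. So does whether any of these compounds acts on these cells at a higher concentration.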